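The source may report more compounds than this note shows. Statements on the series, on what has been measured and on what is new or still open speak of the compounds shown alone.

Measured compounds:

compound 1, `Cc1ccc([C@@H](C)Oc2cc3onc(CCC(=O)O)c3cc2Cl)nc1`: 3.6 h
compound 2, `O=C(O)CCn1c(=O)oc2cc(Cl)c(Cl)cc21`: 4.3 h
compound 3, `CCOc1cc2oc(=O)n(CCC(=O)O)c2cc1Cl`: 0.43 h

The numbers come from an ADME assay on the whole organism (strain Han-Wistar) for metabolic stability, with Rattus norvegicus as the target, read by LC-MS, at a dose of 1 mg/kg by the intravenous route; on this read-out higher numbers stand for a longer-lived compound and lower numbers for a shorter-lived compound. Among the three, compound 1 gives the second highest value; its nearest neighbour is compound 2, whose number lies within the scatter of that of compound 1, and the two cannot be told apart. Compound 3 lies furthest away, well beyond the scatter, with a markedly shorter-lived profile.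

The step of interest leads from compound 1 to the unmeasured compound 4, `C[C@@H](Oc1cc2onc(CCC(=O)O)c2cc1Cl)c1ccccn1`. The change is hydrogen in place of methyl on an aromatic carbon; it sits two atoms from the ring nitrogen, para to a large group.

Going by the values given here, only one measured step exists, a 10-fold lower number from compound 2 to compound 3 (1.00 log units; beyond the scatter). It concerns a different exchange, ethoxy in place of chloro, on a core other than that of compound 1, so it does not speak to the loss of a methyl from an aromatic carbon. Among the compounds with values here, no measured pair bears directly on this change, and a step within the scatter is therefore expected for a 1.2-fold lower number from compound 1 to compound 4 (0.08 log units; within the scatter). Compound 4 is estimated at 3 h in this assay, within a range from 1.5 h to 6 h.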

Compound 4, half-life: 6.6 h
Compound 4: middle estimate off by 2.2-fold (0.34 log units), on the low side; measured number above the stated range.
By their numbers in this assay, from the lowest: compound 3; then compounds 1, 2 and 4 (each within the scatter of the next).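

With pyridin-2-yl standing where compound 1 carries 5-methylpyridin-2-yl, this assay records a 1.8-fold higher number from compound 1 to compound 4 (0.26 log units; within the scatter) and so does not tell the two compounds apart. Going by these compounds alone, this is the first direct reading at this position, two atoms from the ring nitrogen and para to a large group, and it gives no sign that the half-life depends on the methyl there. The earlier step, a 10-fold lower number from compound 2 to compound 3 (1.00 log units; beyond the scatter), concerned another exchange on another core and could not show this; nothing here explains the result in either case.

The compounds shown leave open whether a larger or different group on this carbon, such as ethyl, methoxy or chloro, would also stay within the scatter. They also do not show whether an amine at this place would change the half-life.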